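The compounds below may be only part of what the source reports. "The series", "measured", "known", "first", "only" and "open" are said of these compounds alone.

Measured so far in a functional assay on HepG2 cells (Homo sapiens) for inhibition, read by MTT assay, with a stated time of 72 h; on this read-out higher numbers stand for weaker inhibition and lower numbers for stronger inhibition:
Compound 1 `Cc1noc(C)c1-c1cnc(N)c(Oc2ccc(C(=O)Nc3ccccc3)cc2)n1`: 11800 nM
Compound 2 `Cc1noc(C)c1-c1cnc(N)c(Oc2ccc(C(=O)Nc3cccc(Cl)c3)cc2)n1`: 7300 nM
Compound 3 `Cn1cc(-c2cnc(N)c(Oc3ccc(C(=O)Nc4ccccc4)cc3)n2)cn1`: 11600 nM

Compound 3 sits right beside compound 1, and compound 2 lies within the scatter of both; all three numbers are close together. Compound 4 `Cn1cc(-c2cnc(N)c(Oc3ccc(C(=O)Nc4cccc(Cl)c4)cc3)n2)cn1` differs from compound 3 by one change: chloro in place of hydrogen on an aromatic carbon. The same change has been measured once before, on the other core, as a 1.6-fold lower number from compound 1 to compound 2 (0.21 log units; within the scatter), a step that stayed within the scatter. On that basis only a small shift is expected for compound 4 in this assay, if any, and in the direction of a lower number; the expected step is a 1.5-fold lower number from compound 3 to compound 4 (0.19 log units; within the scatter). Compound 4 is therefore estimated at 7500 nM, with a likely range from 3500 nM to 16000 nM.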

Compound 4, half-maximal inhibitory concentration: 21200 nM
Beside the measured number, compound 4's estimate is 2.8-fold (0.45 log units) below it, outside the stated range (above it).
By their numbers in this assay, from the lowest: compounds 2, 3, 1 and 4 (each within the scatter of the next, the first and the last beyond it).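

In this assay, the change from phenyl to 3-chlorophenyl on the pyrazolyl-bearing core reads a 1.8-fold higher number from compound 3 to compound 4 (0.26 log units; within the scatter), and this does not match the same change on the other core: the same change on two cores in this assay, a 1.6-fold lower number (0.21 log units; within the scatter) from compound 1 to compound 2 and a 1.8-fold higher number (0.26 log units; within the scatter) from compound 3 to compound 4, 3.0-fold (0.47 log units) apart, beyond the scatter of two such steps

With the chloro present, the swap of 3,5-dimethyl-1,2-oxazol-4-yl for 1-methyl-1H-pyrazol-4-yl now reads a 2.9-fold higher number from compound 2 to compound 4 (0.46 log units; beyond the scatter), although it gave no step beyond the scatter without the chloro: the same change on two cores in this assay, a 1.0-fold lower number (0.01 log units; within the scatter) from compound 1 to compound 3 and a 2.9-fold higher number (0.46 log units; beyond the scatter) from compound 2 to compound 4, 3.0-fold (0.47 log units) apart, beyond the scatter of two such steps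

In these four compounds, then, the effects of the two places cannot be read as separate and simply added.

Going by these compounds, whether a fluoro or a methoxy in place of the chloro would depend on the other group in the same way stays open.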